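Adding one double bond to a side chain

A few compounds are considered here, and "the series" means these few. Any claim that something is new, unique, unknown or untested is made for them only; others in the source may bear on it.

Measured so far in an ADME assay on TZM cells (Homo sapiens) for cytotoxicity, read by XTT assay, with a stated time of 4 days; a higher number here means that more compound is tolerated, a lower number that less compound is tolerated:
- compound 1 `Cc1cc(N)cc(C)c1Oc1cc(Nc2ccc(C#N)cc2)c(N)cc1C(F)(F)F` gives 15800 nM
- compound 2 `CC(=O)CCc1cc(C)c(Oc2cc(Nc3ccc(C#N)cc3)c(N)cc2C(F)(F)F)c(C)c1` gives 11100 nM

For the measured compounds named here, only two numbers exist so far, and they cannot be told apart. Going by the values given here, putting 2-acetylethyl in place of amino produced a 1.4-fold lower number from compound 1 to compound 2 (0.15 log units; within the scatter), which leaves compound 2 level with the only other measured compound.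

Compound 3 `CC(=O)/C=C/c1cc(C)c(Oc2cc(Nc3ccc(C#N)cc3)c(N)cc2C(F)(F)F)c(C)c1` keeps the core of compound 2 and alters only that side chain: 2-acetylethenyl in place of 2-acetylethyl on an aromatic carbon. In plain words, 2-acetylethenyl takes the place of 2-acetylethyl on an aromatic carbon.

Among the compounds with values here, the one measured step that bears on this is a 1.4-fold lower number from compound 1 to compound 2 (0.15 log units; within the scatter), and it exchanged a whole group without leaving the scatter. Within the data shown here, no measured pair isolates this double bond, so that single step is a thin guide. Even so, no step beyond the scatter is expected in this assay, and no direction can be favoured with any confidence. The expected step is a 1.1-fold lower number from compound 2 to compound 3 (0.05 log units; within the scatter) and remains only an estimate. Compound 3 is estimated at 10000 nM, with an expected range from 4000 nM to 22000 nM.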

Compound 3, half-maximal cytotoxic concentration: > 8600 nM
Compound 3: only a limit was reported; the forecaster's own chance of this, stated with the estimate: 10%; the middle value does not contradict the limit.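

In this assay compound 3 gives > 8600 nM, which is a limit and not a number. For the compounds shown here, the steps from compound 1 and from compound 2 to compound 3 therefore cannot be read, because the only result for compound 3 is this limit: the limit of > 8600 nM in this assay, at which 1 of the 3 values shown sits. The compounds shown leave open whether 2-acetylethenyl in place of 2-acetylethyl moves the number at all, and in which direction.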